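The source may report more compounds than this note shows. Statements on the series, on what has been measured and on what is new or still open speak of the compounds shown alone.

Compound 1, `C=C1CC(Cn2cc(C)c(=O)[nH]c2=O)(c2ccc(F)cc2)OC1=O`: 9120 nM
Compound 2, `C=C1CC(Cn2ccc(=O)[nH]c2=O)(c2ccc(F)cc2)OC1=O`: 16200 nM

Both numbers come from a functional assay on PC-3 cells (Homo sapiens) for inhibition; a lower number here means a stronger inhibitor of growth, a higher number a weaker inhibitor of growth. On the two numbers shown, compound 2 sits at one end and compound 1 at the other, yet the step of a 1.8-fold higher number from compound 1 to compound 2 (0.25 log units; within the scatter) lies within the scatter, so the two compounds cannot be told apart by this assay.

Compound 3, `C=C1CC(Cn2cc(Br)c(=O)[nH]c2=O)(c2ccc(F)cc2)OC1=O`, has not yet been measured. It differs from compound 2 by bromo in place of hydrogen on an aromatic carbon. Within the data shown here, the only measured step that touches this carbon is a 1.8-fold higher number from compound 1 to compound 2 (0.25 log units; within the scatter), where methyl and hydrogen were exchanged on the same aromatic carbon and the number stayed within the scatter. With one small group already shown to make no difference there, a bromo entering at the same place gives no reason to expect a step in this assay beyond the scatter.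

Compound 3 is therefore expected near 10000 nM, within a range from 4000 nM to 25000 nM. The implied step a 1.6-fold lower number from compound 2 to compound 3 (0.21 log units; within the scatter) is expected to remain within the scatter.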

Compound 3, concentration for 50% growth inhibition: 11700 nM
Compound 3: middle estimate off by 1.2-fold (0.07 log units), on the low side; measured number inside the range.
By their numbers in this assay, from the lowest: compounds 1, 3 and 2 (each within the scatter of the next).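

Among these compounds, on this aromatic carbon, the earlier compounds offered only the exchange of methyl and hydrogen; bromine now adds a third kind of atom there. In this assay, bromo in place of hydrogen gives a 1.4-fold lower number from compound 2 to compound 3 (0.14 log units; within the scatter), and bromo in place of methyl gives a 1.3-fold higher number from compound 1 to compound 3 (0.11 log units; within the scatter), so neither exchange separates the compounds, and hydrogen, methyl and bromo cannot be told apart at this place. No measurement is given that would explain this lack of separation.

On these data alone, whether a group of another kind on the same carbon, such as an amine, a carboxylic acid or a longer chain, would produce a step beyond the scatter remains open. So does whether this carbon stays as unresponsive when the rest of the shared core is changed.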